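Lengthening a sulfur chain from methyl to ethyl

The source may report more compounds than this note shows. Statements on the series, on what has been measured and on what is new or still open speak of the compounds shown alone.

Compound 1 `COc1ccc(-n2c(S)nnc2-c2cc(OC)c(OC)c(OC)c2)cc1` gives 57500 nM
Compound 2 `COc1ccc(-n2c(SC)nnc2-c2cc(OC)c(OC)c(OC)c2)cc1` gives > 60000 nM

Both figures are half-maximal inhibitory concentrations from a functional assay on HepG2 cells (Homo sapiens) for inhibition, read by MTT assay, with a stated time of 48 h (on this read-out higher numbers stand for weaker inhibition and lower numbers for stronger inhibition), and belong to compounds with a shared core. Compound 2 stands at > 60000 nM as a limit of the assay and not as a number.

Compound 3 `CCSc1nnc(-c2cc(OC)c(OC)c(OC)c2)n1-c1ccc(OC)cc1` differs from compound 2 by methyl in place of hydrogen on a saturated chain carbon bound to a sulfur in the sulfur chain. This is methyl in place of hydrogen on a saturated chain carbon bound to a sulfur, which turns methylsulfanyl into ethylsulfanyl.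

Going by the values given here, one measured step bears on this change, methyl in place of hydrogen on a sulfur, which gave an at least 1.0-fold higher number from compound 1 to compound 2 (0.01 log units; that floor lies within the scatter) as its size. That size is only a floor, and caution comes from the limit of > 60000 nM in this assay, at which 1 of the 2 values shown sits, in these data. No step beyond the scatter is therefore expected in this assay and no firm direction can be given. The expected size is a step that the limit leaves unreadable from compound 2 to compound 3 as an estimate. For compound 3 the estimated value is 70000 nM with an expected range from 30000 nM to 160000 nM around that estimate.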

Compound 3, half-maximal inhibitory concentration: > 60000 nM
Compound 3 gave a limit, no number; the forecaster's own chance of this, stated with the estimate: 60%; the middle value is on the limit's open side.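

In this assay compound 3 gives > 60000 nM, which is a limit of the assay and not a number. Placing ethyl instead of hydrogen on the sulfur gives an at least 1.0-fold higher number from compound 1 to compound 3 (0.01 log units; that floor lies within the scatter), so this larger change, like the methyl change before it, provides only a floor and no firm direction. The lengthening from methylsulfanyl to ethylsulfanyl therefore has no readable size, and the result adds a second sulfur chain whose value stays out of reach of the read-out: the limit of > 60000 nM in this assay, at which 2 of the 3 values shown sit.

On these data alone, the step between the two limits cannot be read, so it remains open whether lengthening this chain changes inhibition of the cells at all. Also open, as far as these compounds go, is what a propyl chain, or a chain carrying an amine or a carboxylic acid, would give on this sulfur, and whether any such group would bring the value back within the range where it can be read as a number.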